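Adding a Phenethylsulfanyl Group to Compound 2

A few compounds are considered here, and "the series" means these few. Any claim that something is new, unique, unknown or untested is made for them only; others in the source may bear on it.

compound 1 `Cc1cc(Nc2ccn(Cc3cccc4ccccc34)n2)n2nc(SCc3ccc(Br)cc3)nc2n1`: 5660 nM
compound 2 `Cc1cc(Nc2cc(-c3ccccc3)[nH]n2)n2ncnc2n1`: > 50000 nM
compound 3 `CCCCCc1c(C)nc2nc(SCc3ccc(Cl)cc3)nn2c1Nc1cc(-c2ccccc2)[nH]n1`: > 50000 nM

In a functional assay on PC-9 cells (Homo sapiens) for inhibition, read by MTT assay, with a stated time of 72 h (a higher number here means a weaker inhibitor, a lower number a stronger inhibitor), compound 1 gives 5660 nM. Compound 2 reaches only the limit of the assay, > 50000 nM, so no number of its own is known for it. Compound 3 likewise stops at the assay limit, > 50000 nM. Compound 2 therefore stands at the limit of > 50000 nM in this assay, at which 2 of the 3 values shown sit. Compound 4 `Cc1cc(Nc2cc(-c3ccccc3)[nH]n2)n2nc(SCCc3ccccc3)nc2n1` differs from compound 2 by phenethylsulfanyl in place of hydrogen on an aromatic carbon. Among the measured compounds shown here, no step between two measured compounds that differ in a single place is known here, so the size of the change can only be guessed. The step from compound 2 to compound 4 is expected to run toward stronger inhibition, an at least 2.5-fold lower number from compound 2 to compound 4 (0.39 log units; beyond the scatter), but it may well stay within the scatter. Compound 4 is estimated at 20000 nM, within a range from 4000 nM to 50000 nM.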

Compound 4, half-maximal inhibitory concentration: 4930 nM
The estimate for compound 4 lay 4.1-fold (0.61 log units) above the measured number; measured number inside the range.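

In this assay phenethylsulfanyl on the aromatic carbon between two ring nitrogen atoms brings an at least 10-fold lower number from compound 2 to compound 4 (1.00 log units; beyond the scatter) and this step lies beyond the scatter. It is the only step shown at this position, and it shows that the position accepts a large group with a clear gain. From the compounds shown here alone, for compound 2, > 50000 nM is a limit and not a number, and the full size of the step stays unknown because compound 2 has no number of its own: the limit of > 50000 nM in this assay, at which 2 of the 4 values shown sit.

Going by these compounds, whether the sulfur or the phenyl ring carries the gain stays open. So does whether a methylsulfanyl group or an amine at this position would do the same.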